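The source may hold more compounds than are shown below. What is called first, only, known or untested is meant among the compounds shown, and "the series" means these compounds.

Working notes on the series.

For the measured compounds named here, compound 1 `Cc1ccc(S(=O)(=O)c2cnc3cc(F)ccc3c2-c2cccc(Cl)c2)cc1F` stands at the lower of the two numbers so far: in an ADME assay on microsomes from liver (Homo sapiens) for metabolic stability, tested at 2.5 uM (on this read-out lower numbers stand for slow clearance and higher numbers for fast clearance), compound 1 gives 2.13 mL/min. Going by the values given here, its nearest neighbour is compound 2 `Cc1ccc(S(=O)(=O)c2cnc3cc(F)ccc3c2-c2ccc(F)cc2)cc1F`; in this assay compound 2 gives 2.33 mL/min, and the single measured step is a 1.1-fold higher number from compound 1 to compound 2 (0.04 log units; within the scatter), so the two compounds are not separated on this read-out.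

Compound 3 `O=S(=O)(c1cc(Cl)cc(Cl)c1)c1cnc2cc(F)ccc2c1-c1cccc(Cl)c1` is not yet measured. Its difference from compound 1 is 3,5-dichlorophenyl in place of 3-fluoro-4-methylphenyl on a sulfonyl sulfur. Among the compounds with values here, the one measured step swaps the aryl group on an aromatic carbon, not the aryl group on the sulfonyl sulfur, so it bears on the new change only as a general indication that aryl swaps in this core have so far moved this assay by little. Within the data shown here, no measured step touches the sulfonyl-bound aryl group, which leaves the direction open. The expectation is therefore a step of a 1.2-fold higher number from compound 1 to compound 3 (0.09 log units; within the scatter), not clearly beyond the scatter. Compound 3 is estimated at 2.6 mL/min, with a range from 1.3 mL/min to 5.2 mL/min.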

Compound 3, intrinsic clearance in a liver preparation (reported as CLH), per the amount of preparation that the assay uses: 0.93 mL/min
Beside the measured number, compound 3's estimate is 2.8-fold (0.45 log units) above it; the measured number lies below the stated range.
By their numbers in this assay, from the lowest: compound 3; then compounds 1 and 2 (each within the scatter of the next).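

For the compounds shown here, the sulfonyl sulfur is the first place where an aryl swap moves this assay beyond the scatter: 3,5-dichlorophenyl in place of 3-fluoro-4-methylphenyl gives a 2.3-fold lower number from compound 1 to compound 3 (0.36 log units; beyond the scatter) on this position, while the only other step, a 1.1-fold higher number from compound 1 to compound 2 (0.04 log units; within the scatter) on an aromatic carbon, stays within it. The leaving and entering groups have the same heavy-atom count, the same aromatic ring of carbon only, the same hydrogen-bond donor and acceptor counts and no net charge, so the step goes with a change in ring substituents and not with any change in those counts. Nothing available bears on the reason for this step.

Going by these compounds, a single pair cannot separate the loss of the methyl, the loss of the fluorine and the entry of the chlorines, and compound 1 and compound 3 share the 3-chlorophenyl group, so whether the step holds with 4-fluorophenyl on the aromatic carbon stays open. On these data alone, how this assay responds to a non-aromatic group on the sulfonyl sulfur, such as cyclopropyl or piperidine, or to an aryl group carrying an amine or a carboxylic acid, also stays open.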